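The compounds below may be only part of what the source reports. "The series", "measured", "known", "first", "only" and "open" are said of these compounds alone.

For the measured compounds named here, in an ADME assay on MT4 cells (Homo sapiens) for cytotoxicity (a higher number here means that more compound is tolerated, a lower number that less compound is tolerated), compound 3 `Cc1cc(C)cc(Cn2c(SCC(=O)Nc3ccc(C)cc3Cl)nc3ccccc32)c1` gives 49200 nM, the lowest of the numbers so far. Compound 2 `Cc1cc(C)cc(Cn2c(SCC(=O)Nc3ccccc3[N+](=O)[O-])nc3ccccc32)c1` gives 194000 nM. Compound 1 `Cc1cc(C)cc(Cn2c(SCC(=O)Nc3ccccc3Br)nc3ccccc32)c1` gives >= 143000 nM, which is a limit of the assay and not a number.

The change under study leads to compound 4 `Cc1cc(C)cc(Cn2c(SCC(=O)Nc3ccc(S(C)(=O)=O)cc3Cl)nc3ccccc32)c1`: methylsulfonyl in place of methyl on an aromatic carbon, para to a large group and meta to a chloro group (methylsulfonyl in place of methyl on an aromatic carbon).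

Going by the values given here, two measured steps bear on it, a 3.9-fold lower number from compound 2 to compound 3 (0.60 log units; beyond the scatter) and an at least 2.9-fold lower number from compound 1 to compound 3 (0.46 log units; beyond the scatter). There is also a step that the limit leaves unreadable from compound 1 to compound 2. The first two exchange the whole aryl group on the amide-type nitrogen, so neither isolates the methyl. Their sizes therefore give only a loose guide. Among the compounds with values here, compound 3 is the only measured compound with the 2-chloro-4-methylphenyl group, and compound 4 keeps the chloro but loses the methyl. A modest rise in the number is expected, recovering part of a 3.9-fold lower number from compound 2 to compound 3 (0.60 log units; beyond the scatter), though a result within the scatter would not be surprising. The expected step is a 1.8-fold higher number from compound 3 to compound 4 (0.26 log units; within the scatter). The estimate for compound 4 is 90000 nM, with an expected range of 35000 nM to 220000 nM.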

Compound 4, half-maximal cytotoxic concentration: 106000 nM
Compound 4: the middle estimate sits 1.2-fold (0.07 log units) below what was measured; measured number inside the range.
By their numbers in this assay, from the lowest: compound 3; then compounds 4 and 2 (each within the scatter of the next).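

In this assay, for the compounds shown here, the aromatic carbon para to a large group and meta to a chloro group affects the read-out on its own: with the chloro group held fixed, methylsulfonyl in place of methyl gives a 2.2-fold higher number from compound 3 to compound 4 (0.33 log units; beyond the scatter), the first step that isolates this position. The exchange of the whole aryl group gives a 1.8-fold lower number from compound 2 to compound 4 (0.26 log units; within the scatter), so 2-chloro-4-(methylsulfonyl)phenyl stays level with 2-nitrophenyl in this assay, whereas 2-chloro-4-methylphenyl stood apart from it. Compound 1 carries a limit and not a number, so an at least 1.3-fold lower number from compound 1 to compound 4 (0.13 log units; that floor lies within the scatter) gives only a floor: the limit of >= 143000 nM in this assay, at which 1 of the 4 values shown sits.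

As far as these compounds go, this position rests on a single pair, so it remains open whether the step follows from the methylsulfonyl group entering or from the methyl group leaving. An amine, a carboxylic acid or a methoxy group at the same carbon, and methylsulfonyl paired with a bromo group in place of the chloro group, would show how far the step in compound 4 is specific to this combination.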